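From cyclohexyl to 3-methylphenyl on a shared core

This account rests on a few compounds, and the source may have more. Where it says the series, first, only, none or still open, it means among the compounds named here.

Compound 1 `C[C@H](Nc1c(NCCCCCC(=O)NO)c(=O)c1=O)c1ccccc1` gives 73000000 nM
Compound 2 `O=C(CCCCCNc1c(NC2CCCCC2)c(=O)c1=O)NO` gives 91000000 nM

Going by the values given here, in a physicochemical assay for solubility, read by HPLC, in phosphate buffer, with a stated time of 24 h, at pH 7.4, tested at 100 uM (a higher number here means a more soluble compound, a lower number a less soluble compound), compound 2 stands at 91000000 nM and lies within the scatter of compound 1, the only other measured compound, at 73000000 nM on the same scale. Compound 3 (`Cc1cccc(Nc2c(NCCCCCC(=O)NO)c(=O)c2=O)c1`) has not yet been measured. It carries 3-methylphenyl in place of cyclohexyl on a nitrogen on an aromatic ring. Among the compounds with values here, one measured step bears on this change, a swap at the same place between cyclohexyl and 1-phenylethyl: a 1.2-fold higher number from compound 1 to compound 2 (0.10 log units; within the scatter). That is a single case, and 1-phenylethyl is not 3-methylphenyl, so it guides the expectation only loosely. On that evidence, no step beyond the scatter is expected in this assay, and the estimated step is small (a 1.5-fold lower number from compound 2 to compound 3 (0.18 log units; within the scatter)). Within the data shown here, the range is kept wide, since no measured compound carries 3-methylphenyl. Compound 3 is estimated at 60000000 nM in this read-out of solubility (expected range 20000000 nM to 100000000 nM).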

Compound 3, solubility: 79000000 nM
Beside the measured number, compound 3's estimate is 1.3-fold (0.12 log units) below it, and the stated range covers the measured number.
By their numbers in this assay, from the lowest: compounds 1, 3 and 2 (each within the scatter of the next).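

In this assay, 3-methylphenyl in place of cyclohexyl on a nitrogen on an aromatic ring gives a 1.2-fold lower number from compound 2 to compound 3 (0.06 log units; within the scatter) and 3-methylphenyl in place of 1-phenylethyl at the same place gives a 1.1-fold higher number from compound 1 to compound 3 (0.03 log units; within the scatter) on the same scale. Until now this place had offered a single step, and the second and third steps extend the picture: a six-membered aromatic ring of carbon only can stand where a six-membered non-aromatic ring of carbon only stood, with no step beyond the scatter, and all three compounds lie within the scatter of one another. Nothing measured among these compounds explains this result.

Cyclohexyl and 3-methylphenyl both count no hydrogen-bond donors, no hydrogen-bond acceptors and no net charge, so the compounds shown leave open whether this flat picture would hold for a group at this nitrogen that carries an amine or a carboxylic acid. They also leave open whether the three groups would still sit this close together on a core with a longer chain.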